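This account rests on a few compounds, and the source may have more. Where it says the series, first, only, none or still open, it means among the compounds named here.

Working notes on the series. In a functional assay for inhibition, with Homo sapiens as the target (on this read-out higher numbers stand for weaker inhibition and lower numbers for stronger inhibition), compound 1 `COCc1cc(-c2ccccc2)c2ccc(OCc3cccc(C4(O)CCOCC4)c3)cc2c1` gives 4 nM, and compound 2 `COC(=O)c1cc(-c2ccccc2)c2ccc(OCc3cccc(C4(O)CCOCC4)c3)cc2c1` gives 3 nM, so the two values lie within the scatter of each other. Compound 3 `Cn1nnc(-c2cc(-c3ccccc3)c3ccc(OCc4cccc(C5(O)CCOCC5)c4)cc3c2)n1` is still unmeasured. It carries 2-methyl-2H-tetrazol-5-yl in place of methoxymethyl on an aromatic carbon.

Within the data shown here, only one measured step bears on this position: a 1.3-fold lower number from compound 1 to compound 2 (0.12 log units; within the scatter), with methoxycarbonyl in place of methoxymethyl on an aromatic carbon. That replacement stayed within the scatter. Among the measured compounds shown here, no measured compound carries the 2-methyl-2H-tetrazol-5-yl group, however, so this single step gives only weak support.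

The step expected in this assay is no change at the digits printed from compound 1 to compound 3 (within the scatter), with no shift beyond the scatter in either direction. For compound 3 the estimated value is 4 nM, with an expected range of 1.5 nM to 15 nM.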

Compound 3, half-maximal inhibitory concentration: 4 nM
Beside the measured number, compound 3's estimate shows no gap at the digits printed; the measured number falls inside the stated range.
By their numbers in this assay, from the lowest: compounds 2, 1 and 3 (each within the scatter of the next).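

In this assay the aromatic carbon now carries 2-methyl-2H-tetrazol-5-yl, one five-membered aromatic ring with 4 hetero atoms, in place of the open methoxymethyl chain, and the step is no change at the digits printed from compound 1 to compound 3 (within the scatter); against the methoxycarbonyl group it is a 1.3-fold higher number from compound 2 to compound 3 (0.12 log units; within the scatter). This position has therefore held three different groups, including a ring of 6 heavy atoms, with no shift beyond the scatter among compounds 1, 2 and 3. No measured data on the series offer an explanation for this flat result.

The compounds shown leave open whether a carboxylic acid or an amine on this aromatic carbon would also stay within the scatter of these three. They also leave open whether the flat result would persist with a small alkyl chain in place of the phenyl group.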